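The source may hold more compounds than are shown below. What is called first, only, known or untested is meant among the compounds shown, and "the series" means these compounds.

Compound 1 `CCN(C(=O)CCC(=O)Nc1ccc(-c2ccc(OCC(=O)O)cc2)cc1Cl)c1ccc(C(C)(C)C)cc1Cl` gives 0.1 h in an in vitro ADME assay on microsomes from liver (Homo sapiens) for metabolic stability (a lower number here means that the compound disappears faster, a higher number that the compound lasts longer), the lowest of the three numbers in hand. Compound 2 `C=CCN(C(=O)CCC(=O)Nc1ccc(-c2ccc(OCC(=O)O)cc2)cc1Cl)c1ccc(C(C)(C)C)cc1Cl` gives 0.15 h in this assay, and compound 3 `CC(C)(C)c1ccc(N(C(=O)CCC(=O)Nc2ccc(-c3ccc(OCC(=O)O)cc3)cc2Cl)C2CC2)c(Cl)c1` gives 0.25 h. The measured steps are a 1.5-fold higher number from compound 1 to compound 2 (0.18 log units; within the scatter), a 2.5-fold higher number from compound 1 to compound 3 (0.40 log units; beyond the scatter) and a 1.7-fold higher number from compound 2 to compound 3 (0.22 log units; within the scatter); each of them alters only the group on the amide-type nitrogen. Compound 4 `CCN(C(=O)CCC(=O)Nc1ccc(-c2ccc(CC(=O)O)cc2)cc1Cl)c1ccc(C(C)(C)C)cc1Cl` differs from compound 1 at a different place: carboxymethyl in place of carboxymethoxy on an aromatic carbon. Among the measured compounds shown here, none of the measured steps touches that part of the shared core, so nothing in hand speaks for a step beyond the scatter, and the estimated step is no change at the digits printed from compound 1 to compound 4 (within the scatter). The expected value for compound 4 in this assay is 0.1 h, with a range from 0.05 h to 0.25 h.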

Compound 4, half-life: 0.05 h
Compound 4: middle estimate off by 2.0-fold (0.30 log units), on the high side; measured number inside the range.
By their numbers in this assay, from the lowest: compounds 4, 1, 2 and 3 (each within the scatter of the next, the first and the last beyond it).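

In this assay carboxymethyl in place of carboxymethoxy, on an aromatic carbon para to a large group, gives a 2.0-fold lower number from compound 1 to compound 4 (0.30 log units; within the scatter) as the first reading away from the amide-type nitrogen. This pair therefore does not separate the two groups at this position, and the change stays short of a step beyond the scatter. No measurement in hand bears on the reason for this reading.

Open, on these data alone, is whether a longer chain ending in a carboxylic acid, or a primary amide in place of the acid, would read differently here. Also open, as far as these compounds go, is whether the same change reads alike with cyclopropyl on the amide-type nitrogen.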